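Amine Ring Size and Cytotoxicity: Notes on Four Compounds

This account rests on a few compounds, and the source may have more. Where it says the series, first, only, none or still open, it means among the compounds named here.

Compound 1 `CCN(CC)CCC(=O)OC1CC2(N3CCCC3)CC(c3ccccc3)C1C(c1ccccc1)C2`, compound 2 `CCN(CC)CCC(=O)OC1CC2(N3CCCCC3)CC(c3ccccc3)C1C(c1ccccc1)C2` and compound 3 `O=C(CCN1CCCCC1)OC1CC2(N3CCCC3)CC(c3ccccc3)C1C(c1ccccc1)C2` have been measured; compound 4 `O=C(CCN1CCCCC1)OC1CC2(N3CCCCC3)CC(c3ccccc3)C1C(c1ccccc1)C2` has not. In an ADME assay on L6 cells (Rattus norvegicus) for cytotoxicity (a lower number here means a stronger inhibitor, a higher number a weaker inhibitor), compound 1 gives 19200 nM, compound 2 gives 22900 nM and compound 3 gives 17800 nM. The change piperidin-1-yl in place of pyrrolidin-1-yl on a saturated ring carbon gave a 1.2-fold higher number from compound 1 to compound 2 (0.08 log units; within the scatter). Compound 3 differs from compound 1 by piperidin-1-yl in place of diethylamino on a saturated chain carbon, two bonds along the chain from a carbonyl carbon, which gave a 1.1-fold lower number from compound 1 to compound 3 (0.03 log units; within the scatter). Compound 4 arises from compound 3 by piperidin-1-yl in place of pyrrolidin-1-yl on a saturated ring carbon, the same kind of change as that between compound 1 and compound 2; the surroundings differ only in that the ring atom two ring bonds from the place bears a ((2-(piperidin-1-yl)ethyl)carbonyl)oxy group rather than a ((2-(diethylamino)ethyl)carbonyl)oxy group. For compound 4 a step of a 1.2-fold higher number from compound 3 to compound 4 (0.07 log units; within the scatter) in this assay is expected, resting on a 1.2-fold higher number from compound 1 to compound 2 (0.08 log units; within the scatter). Compound 4 is therefore estimated at 21000 nM, with a likely range from 12000 nM to 37000 nM.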

Compound 4, half-maximal inhibitory concentration: 54600 nM
The estimate for compound 4 lay 2.6-fold (0.41 log units) below the measured number; the whole stated range lies below it.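

In this assay, piperidin-1-yl in place of pyrrolidin-1-yl on a saturated ring carbon gives a 3.1-fold higher number from compound 3 to compound 4 (0.49 log units; beyond the scatter), and this step does not differ from the earlier one by more than the scatter allows: the same change on two cores in this assay, a 1.2-fold higher number (0.08 log units; within the scatter) from compound 1 to compound 2 and a 3.1-fold higher number (0.49 log units; beyond the scatter) from compound 3 to compound 4, 2.6-fold (0.41 log units) apart, within the scatter of two such steps. Piperidin-1-yl in place of diethylamino gives a 2.4-fold higher number from compound 2 to compound 4 (0.38 log units; beyond the scatter), and the comparison reads the same way: the same change on two cores in this assay, a 1.1-fold lower number (0.03 log units; within the scatter) from compound 1 to compound 3 and a 2.4-fold higher number (0.38 log units; beyond the scatter) from compound 2 to compound 4, 2.6-fold (0.41 log units) apart, within the scatter of two such steps. Each comparison rests on a single pair of steps: no dependence on the core is shown, and neither is an unchanged transfer from one core to the other.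

Open, as far as these compounds go, is whether the number for compound 4 depends on having both piperidin-1-yl groups together. Also open, from the compounds shown here alone, is whether a morpholin-4-yl group or a longer chain between the carbonyl and the amine would follow the same steps.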